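This account rests on a few compounds, and the source may have more. Where it says the series, first, only, none or still open, it means among the compounds named here.

Measured compounds:
- compound 1, `CCO/C(O)=C1\C(COCCN(C)C(=O)NC)=NC(C)=C(C(=O)OC)C1c1ccccc1Cl`, in a functional assay (aorta) with Rattus norvegicus as the target (on this read-out higher numbers stand for weaker inhibition and lower numbers for stronger inhibition), compound 1 gives 20 nM
- compound 2, `CCOC(=O)CNC(=O)NCCOCC1=C(C(=O)OCC)C(c2ccccc2Cl)/C(=C(\O)OC)C(C)=N1`, in this assay compound 2 gives 10 nM

Among the compounds with values here, on these two numbers compound 1 has the higher value, and the only neighbour is compound 2, whose value differs from it by an amount that stays within the usual scatter of repeated measurements, so the two compounds cannot be placed in order on this assay.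

Compound 3, `CCO/C(O)=C1\C(COCC/N=C(/NC)NC#N)=NC(C)=C(C(=O)OC)C1c1ccccc1Cl`, has not been measured. It differs from compound 1 in a single place: a group of 7 heavy atoms (3 carbon, 4 nitrogen; no ring) in place of a group of 6 heavy atoms (3 carbon, 2 nitrogen, 1 oxygen; no ring), on a saturated chain carbon, two bonds along the chain from an oxygen on a saturated carbon. Within the data shown here, no step between two measured compounds covers such a change, so nothing in the data shows how this exchange on the side chain moves the result on this assay. The expectation for compound 3 is therefore a step of no size beyond the scatter, no change at the digits printed from compound 1 to compound 3 (within the scatter). Compound 3 is estimated to give 20 nM, with a range from 5 nM to 80 nM.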

Compound 3, half-maximal inhibitory concentration: 6.31 nM
The estimate for compound 3 lay 3.2-fold (0.50 log units) above the measured number, within the range that was stated.
By their numbers in this assay, from the lowest: compounds 3, 2 and 1 (each within the scatter of the next, the first and the last beyond it).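

At the saturated chain carbon, two bonds along the chain from an oxygen on a saturated carbon, the side chain proves able to move the result: in this assay, putting the group of 7 heavy atoms in place of methyl(methylcarbamoyl)amino gives a 3.2-fold lower number from compound 1 to compound 3 (0.50 log units; beyond the scatter) and this step lies beyond the scatter. Within the data shown here, the earlier compounds offered no step at this place, so this is the first sign that an exchange here can shift the read-out, and the shift is toward stronger inhibition. Nothing at hand accounts for the step.

Going by these compounds, with a single exchange at this place, it remains open whether the nitrile of the entering group plays any part in the step. On these data alone, it also remains open whether a plain amine, a carboxylic acid or a longer chain at the same carbon would move the number as far, less far or the other way.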